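A few compounds are considered here, and "the series" means these few. Any claim that something is new, unique, unknown or untested is made for them only; others in the source may bear on it.

In a functional assay on NCI-H460 cells (Homo sapiens) for cytotoxicity, read by MTT assay, with a stated time of 72 h (a lower number here means a stronger inhibitor, a higher number a weaker inhibitor), three analogues built on one shared core have been measured. Compound 1 `CN(C)CCn1cnnc1-c1cc(Oc2ccc(NC(=O)N/N=C/c3c(Cl)cccc3Cl)cc2F)ccn1` gives 350 nM. Compound 2 `CN(C)CCn1cnnc1-c1cc(Oc2ccc(NC(=O)N/N=C/c3c[nH]c4ccccc34)cc2F)ccn1` gives 1630 nM. Compound 3 `COc1ccc(/C=N/NC(=O)Nc2ccc(Oc3ccnc(-c4nncn4CCN(C)C)c3)c(F)c2)c(OC)c1` gives 1570 nM, the second highest of the three numbers; its nearest neighbour is compound 2, which it matches within the scatter, and its furthest is compound 1. The measured steps are a 4.7-fold higher number from compound 1 to compound 2 (0.67 log units; beyond the scatter), a 4.5-fold higher number from compound 1 to compound 3 (0.65 log units; beyond the scatter) and a 1.0-fold lower number from compound 2 to compound 3 (0.02 log units; within the scatter), and each exchanges the whole aryl group on a carbon with a double bond to nitrogen. Compound 4 `COc1ccc(/C=N/NC(=O)Nc2ccc(Oc3ccnc(-c4nncn4CCN(C)C)c3)c(F)c2)c(OC)c1OC` differs from compound 3 by methoxy in place of hydrogen on an aromatic carbon. Among the measured compounds shown here, no measured step adds a single methoxy group to an otherwise unchanged aryl ring, so none bears directly on this change; compound 2 and compound 3 sit within the scatter of each other, and only compound 1 stands apart. Compound 4 is therefore expected to show no step beyond the scatter, a 1.0-fold lower number from compound 3 to compound 4 (0.02 log units; within the scatter). Compound 4 is estimated at 1500 nM, within 600 nM to 4000 nM.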

Compound 4, half-maximal inhibitory concentration: 1790 nM
The estimate for compound 4 lay 1.2-fold (0.08 log units) below the measured number, and the stated range covers the measured number.
By their numbers in this assay, from the lowest: compound 1; then compounds 3, 2 and 4 (each within the scatter of the next).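

In this assay, methoxy in place of hydrogen on the aromatic carbon ortho to two methoxy groups gives a 1.1-fold higher number from compound 3 to compound 4 (0.06 log units; within the scatter), so this first single-group change on the aryl ring leaves the number within the scatter. The 2,3,4-trimethoxyphenyl group also matches 1H-indol-3-yl, with a 1.1-fold higher number from compound 2 to compound 4 (0.04 log units; within the scatter), while 2,6-dichlorophenyl remains apart, with a 5.1-fold higher number from compound 1 to compound 4 (0.71 log units; beyond the scatter), making compound 1 the only one of the four separated from the rest. No accompanying measurement offers an explanation for this pattern.

The compounds shown leave open whether this aromatic carbon would accept an amine, a carboxylic acid or a longer chain such as butoxy equally well. They also leave open whether a phenyl ring bearing a single chlorine would give a number like that of compound 1 or like those of the other three.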